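This account rests on a few compounds, and the source may have more. Where it says the series, first, only, none or still open, it means among the compounds named here.

Compound 1 `Nc1ccccc1-c1ncc(C(=O)O)c(=O)[nH]1` and compound 2 `C=CCOc1ccccc1-c1ncc(C(=O)O)c(=O)[nH]1` share one core and differ at a single aromatic carbon. In a functional assay on the whole organism (strain Sprague-Dawley) for inhibition, with Rattus norvegicus as the target, with a stated time of 10 min (on this read-out higher numbers stand for an effect only at larger amounts of compound and lower numbers for an effect already at smaller amounts), compound 1 gives 50 mg/kg, the higher of the two numbers, while compound 2 gives 0.5 mg/kg. That one change produced a 100-fold lower number from compound 1 to compound 2 (2.00 log units; beyond the scatter). Compound 3 `CSc1ccccc1-c1ncc(C(=O)O)c(=O)[nH]1` carries yet another group at that aromatic carbon: methylsulfanyl in place of amino on an aromatic carbon. Within the data shown here, only the step from compound 1 to compound 2 bears on this change, and it was large, so a sizeable drop from compound 1 is expected in this assay, though the full size of that step need not carry over. Compound 3 is estimated at 3 mg/kg, within a range from 0.5 mg/kg to 20 mg/kg. That estimate means a 17-fold lower number from compound 1 to compound 3 (1.22 log units; beyond the scatter).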

Compound 3, dose for 50% inhibition: > 20 mg/kg
Compound 3: only a limit was reported; the forecaster's own chance of this, stated with the estimate: 5%; at least 6.6-fold (0.82 log units) between middle value and limit.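

Compound 3 gives only a limit of the assay and not a number: the limit of > 20 mg/kg in this assay, at which 1 of the 3 values shown sits. At this aromatic carbon, methylsulfanyl in place of allyloxy gives an at least 40-fold higher number from compound 2 to compound 3 (1.60 log units; beyond the scatter) in this assay and shows that the low number of compound 2 does not extend to every group replacing amino. As far as these compounds go, the step between compound 1 and compound 3 cannot be read, so how methylsulfanyl ranks against amino stays unknown. Also open, from the compounds shown here alone, is whether methoxy, or a longer chain such as propoxy, would keep the low number of compound 2.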